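Side-chain change from compound 3 to compound 4

This account rests on a few compounds, and the source may have more. Where it says the series, first, only, none or still open, it means among the compounds named here.

In an ADME assay on L6 cells (Rattus norvegicus) for cytotoxicity, read by fluorescence, with a stated time of 72 h (on this read-out higher numbers stand for weaker inhibition and lower numbers for stronger inhibition), compound 1 (`CCN(CC)C(=O)CNC1CC2(N3CCN(C)CC3)CC(c3ccccc3)C1C(c1ccccc1)C2`) gives 37900 nM and compound 2 (`CN1CCN(C23CC(NC(=O)CN4CCCC4)C(C(c4ccccc4)C2)C(c2ccccc2)C3)CC1`) gives 27800 nM while compound 3 (`CCN(CC)CC(=O)NC1CC2(N3CCN(C)CC3)CC(c3ccccc3)C1C(c1ccccc1)C2`) gives 26400 nM and stands within the scatter of both. The steps of a 1.4-fold lower number from compound 1 to compound 2 (0.13 log units; within the scatter) and a 1.4-fold lower number from compound 1 to compound 3 (0.16 log units; within the scatter) stay within the scatter, and so does the closest in kind, a 1.1-fold lower number from compound 2 to compound 3 (0.02 log units; within the scatter) on exchange of pyrrolidin-1-yl for diethylamino. The change to compound 4 (`CN1CCN(C23CC(NC(=O)CCN4CCCCC4)C(C(c4ccccc4)C2)C(c2ccccc2)C3)CC1`) is (piperidin-1-yl)methyl in place of diethylamino on a saturated chain carbon bound to a carbonyl carbon with (piperidin-1-yl)methyl in place of diethylamino on a saturated chain carbon bound to a carbonyl carbon. Among the measured compounds shown here, no measured step covers this group, so no step beyond the scatter is expected in this assay on this thin basis. The estimated step is a 1.1-fold lower number from compound 3 to compound 4 (0.04 log units; within the scatter) and remains an expectation. Compound 4 is expected at 24000 nM (estimated range 11000 nM to 45000 nM).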

Compound 4, half-maximal inhibitory concentration: 15400 nM
The estimate for compound 4 lay 1.6-fold (0.19 log units) above the measured number; measured number inside the range.
By their numbers in this assay, from the lowest: compounds 4, 3, 2 and 1 (each within the scatter of the next, the first and the last beyond it).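

In this assay, going from the (diethylamino)methyl to the 2-(piperidin-1-yl)ethyl side chain gives a 1.7-fold lower number from compound 3 to compound 4 (0.23 log units; within the scatter), and (piperidin-1-yl)methyl in place of pyrrolidin-1-yl gives a 1.8-fold lower number from compound 2 to compound 4 (0.26 log units; within the scatter), so this position tolerates a six-membered ring on the longer chain without a step beyond the scatter. Among the compounds shown here, only (2-(piperidin-1-yl)ethyl)carbonyl in place of (diethylcarbamoyl)methyl on an amine nitrogen gives a modest step beyond it, a 2.5-fold lower number from compound 1 to compound 4 (0.39 log units; beyond the scatter), the first such step. No measurement bears on the cause of these steps.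

Ring and chain length change together here, so their separate contributions remain open. A 2-(diethylamino)ethyl or 2-(morpholin-4-yl)ethyl group would separate them.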